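A few compounds are considered here, and "the series" means these few. Any claim that something is new, unique, unknown or untested is made for them only; others in the source may bear on it.

Measured in a functional assay on VCaP cells (Homo sapiens) for antiproliferative activity, read by CCK-8 assay, with a stated time of 6 days; on this read-out lower numbers stand for stronger inhibition and higher numbers for weaker inhibition:
Compound 1 `CC(O)c1ccc(C(=O)N[C@@H](C)Cn2ccc(-c3ccc(C#N)c(Cl)c3)n2)cc1`: 910 nM
Compound 2 `C[C@@H](Cn1ccc(-c2ccc(C#N)c(Cl)c2)n1)NC(=O)c1cccc(OCC(O)CO)c1`: 590 nM
Compound 3 `C[C@@H](Cn1ccc(-c2ccc(C#N)c(Cl)c2)n1)NC(=O)c1ccccc1F`: 2190 nM

Compound 3, at 2190 nM, has the highest number of the three, and its gaps to compound 1 and compound 2 both lie beyond the scatter. The next compound, compound 4 `C[C@@H](Cn1ccc(-c2ccc(C#N)c(Cl)c2)n1)NS(=O)(=O)c1cn(C)cn1`, has not yet been measured. It keeps the shared core but carries (1-methyl-1H-imidazol-4-yl)sulfonyl in place of (2-fluorophenyl)carbonyl on an amine nitrogen.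

Among the measured compounds shown here, the only measured step that bears on this change is a 2.4-fold higher number from compound 1 to compound 3 (0.38 log units; beyond the scatter). This step is modest, and in it the carbonyl stays while the group attached to it changes. For the measured compounds named here, no measured compound carries a sulfonyl group, so this step offers only a rough guide to size and does not settle the direction. Compound 3 does sit at the top of the measured values, which makes a small move downward slightly more likely than a further rise.

The expected change in this assay is a 1.4-fold lower number from compound 3 to compound 4 (0.14 log units; within the scatter), which would be no step beyond the scatter. Compound 4 is estimated at 1600 nM, with an expected range from 450 nM to 6000 nM.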

Compound 4, half-maximal inhibitory concentration: 13600 nM
Compound 4: middle estimate off by 8.5-fold (0.93 log units), on the low side; measured number outside the range, above it.
By their numbers in this assay, from the lowest: compounds 2 and 1 (each within the scatter of the next); then compound 3; then compound 4.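

In this assay, among the compounds shown here, the three earlier compounds all hold a carbonyl on the amine nitrogen, and the change to (1-methyl-1H-imidazol-4-yl)sulfonyl in place of (2-fluorophenyl)carbonyl gives a 6.2-fold higher number from compound 3 to compound 4 (0.79 log units; beyond the scatter) and so takes that carbonyl away for the first time in this set. The number rises even though the two groups match in heavy-atom count, so here the weaker inhibition goes with a change in the kind of group and not with a change in its number of heavy atoms. Nothing at hand explains why the number rises.

This single step swaps the carbonyl for a sulfonyl and the 2-fluorophenyl ring for a 1-methylimidazole ring together, so the compounds shown cannot tell which of the two changes accounts for the rise. A (2-fluorophenyl)sulfonyl group or a (1-methyl-1H-imidazol-4-yl)carbonyl group on the same nitrogen would separate the two changes, and a simple methylsulfonyl group would show how a sulfonyl fares without any ring attached.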